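The compounds below may be only part of what the source reports. "The series", "measured", "known", "first", "only" and "open" are said of these compounds alone.

Measured so far:
Compound 1 `C=CC(=O)Nc1cccc(-n2c(=O)cc(C)c3cnc(Nc4ccccc4Nc4nc5c(s4)CN(C)CC5)nc32)c1` gives 95 mL/min/kg in an ADME assay on the whole organism (strain Sprague-Dawley) for pharmacokinetics, with Rattus norvegicus as the target, read by LC-MS, at a dose of 5 mg/kg by the intravenous route; on this read-out higher numbers stand for fast clearance and lower numbers for slow clearance.
Compound 2 `C=CC(=O)Nc1cc(-n2c(=O)cc(C)c3cnc(Nc4ccc(N5CCN(C)C(C)C5)cc4OC)nc32)cc(C(F)(F)F)c1` gives 37.5 mL/min/kg in this assay.

Going by the values given here, of these two numbers, compound 2 stands lowest; the only other number, that of compound 1, lies above it by more than the usual scatter. Compound 3 `C=CC(=O)Nc1cccc(-n2c(=O)cc(C)c3cnc(Nc4ccc(N5CCN(C)C(C)C5)cc4OC)nc32)c1` has not yet been measured. It differs from compound 2 in one place: hydrogen in place of trifluoromethyl on an aromatic carbon. Among the compounds with values here, no measured pair shows this change, so its effect is unknown here. The step from compound 2 to compound 3 is expected to be small, at most a modest move toward faster clearance, as a 1.2-fold higher number from compound 2 to compound 3 (0.08 log units; within the scatter). Compound 3 is thus expected to give about 45 mL/min/kg, between 25 mL/min/kg and 80 mL/min/kg.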

Compound 3, clearance: 197 mL/min/kg
Compound 3: middle estimate off by 4.4-fold (0.64 log units), on the low side, outside the stated range (above it).
By their numbers in this assay, from the lowest: compound 2; then compound 1; then compound 3.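

In this assay, this aromatic carbon, meta to the (vinylcarbonyl)amino group, proves sensitive: hydrogen in place of trifluoromethyl gives a 5.3-fold higher number from compound 2 to compound 3 (0.72 log units; beyond the scatter). A single change at this one place is thus enough to move the compound from slower to much faster clearance. Nothing available explains why the number rises.

From the compounds shown here alone, it remains open whether a smaller group here, such as a fluorine atom or a methyl group, would keep clearance low. Also open, going by these compounds, is whether a nitrile at this carbon would behave like trifluoromethyl or like hydrogen.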